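Lengthening the hydroxycarbamoyl chain on a shared core

The compounds below may be only part of what the source reports. "The series", "measured", "known", "first", "only" and "open" are said of these compounds alone.

These compounds share one core and differ in the chain attached to it through an oxygen. In a functional assay on HCT-116 cells (Homo sapiens) for inhibition, read by MTT assay, with a stated time of 48 h (on this read-out lower numbers stand for stronger inhibition and higher numbers for weaker inhibition), compound 1 `O=S(=O)(c1ccccc1)c1c(OCCCCCCO)no[n+]1[O-]` has the entry "not determined" (no result reported), so it offers no number to compare. Compound 2 `O=C(CCCOc1no[n+]([O-])c1S(=O)(=O)c1ccccc1)NO` gives 3830 nM. Compound 3 `O=C(CCCCOc1no[n+]([O-])c1S(=O)(=O)c1ccccc1)NO` gives 2180 nM. Among the compounds with values here, these are the only two numbers so far, and compound 3 cannot be told apart from compound 2: the step, a 1.8-fold lower number from compound 2 to compound 3 (0.24 log units; within the scatter), is no larger than repeat measurements would produce.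

Compound 4 `O=C(CCCCCCOc1no[n+]([O-])c1S(=O)(=O)c1ccccc1)NO` has not been measured yet. Its difference from compound 3 is 2-(hydroxycarbamoyl)ethyl in place of hydroxycarbamoyl on a saturated chain carbon, four bonds along the chain from an oxygen on an aromatic ring. In words, 2-(hydroxycarbamoyl)ethyl stands in place of hydroxycarbamoyl on a saturated chain carbon, four bonds along the chain from an oxygen on an aromatic ring. Within the data shown here, only one measured step bears on this, a similar lengthening that put (hydroxycarbamoyl)methyl in place of hydroxycarbamoyl, and it amounted to a 1.8-fold lower number from compound 2 to compound 3 (0.24 log units; within the scatter). A single step within the scatter sets no firm trend, so only a small drift towards lower numbers is expected, with no change beyond the scatter. In this assay the estimated step is a 1.5-fold lower number from compound 3 to compound 4 (0.16 log units; within the scatter). For compound 4 the expected value is 1500 nM, within an estimated range of 500 nM to 4000 nM.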

Compound 4, half-maximal inhibitory concentration: 4690 nM
The estimate for compound 4 lay 3.1-fold (0.50 log units) below the measured number, outside the stated range (above it).
By their numbers in this assay, from the lowest: compounds 3, 2 and 4 (each within the scatter of the next, the first and the last beyond it).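

In this assay, within the data shown here, the chain at this place does not simply improve as it grows: putting 2-(hydroxycarbamoyl)ethyl in place of hydroxycarbamoyl gives a 2.2-fold higher number from compound 3 to compound 4 (0.33 log units; beyond the scatter) and is the first step here to pass beyond the scatter, although only modestly. Among these compounds, the two ends of the series cannot be told apart, with a 1.2-fold higher number from compound 2 to compound 4 (0.09 log units; within the scatter) as the step between them, so these three hydroxycarbamoyl chains show no steady direction with length, and only the pair of compound 3 and compound 4 differs by more than repeat measurements would. No measurement in hand explains the rise in the number at this step.

Still open, going by these compounds, is how the number behaves for a chain of a length lying between those of compound 3 and compound 4, and for a longer chain ending in hydroxycarbamoyl. Open too, on these data alone, is whether hydroxycarbamoyl matters at all, since compound 1, whose chain ends in a hydroxyl, offers no number, and a carboxylic acid or an amine at the chain end would be the direct test of that group.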